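Compound 3 to compound 4: carbamoyl returns

The compounds below may be only part of what the source reports. "The series", "measured", "known", "first", "only" and "open" are said of these compounds alone.

In a functional assay on KBVIN cells (Homo sapiens) for antiproliferative activity, read by sulforhodamine B assay, with a stated time of 3 days (a lower number here means a stronger inhibitor of growth, a higher number a weaker inhibitor of growth), compound 3 (`COCC(=O)Nc1cccc(Nc2ncc(F)c(Nc3ccc(F)cc3)n2)c1`) gives 3940 nM, the lowest of three numbers. Compound 1 (`O=C(Nc1ccccn1)c1cccc(Nc2ncc(F)c(Nc3ccc(F)cc3)n2)c1`) gives 13700 nM and compound 2 (`COc1ccc(NC(=O)c2cccc(Nc3ncc(F)c(Nc4ccc(F)cc4)n3)c2)cc1`) gives 15700 nM. Their step reads a 1.1-fold higher number from compound 1 to compound 2 (0.06 log units; within the scatter). Compound 4 (`O=C(NCCO)c1cccc(Nc2ncc(F)c(Nc3ccc(F)cc3)n2)c1`) carries (2-hydroxyethyl)carbamoyl in place of ((methoxymethyl)carbonyl)amino on an aromatic carbon. Within the data shown here, two measured steps bear on this: a 3.5-fold lower number from compound 1 to compound 3 (0.54 log units; beyond the scatter) and a 4.0-fold lower number from compound 2 to compound 3 (0.60 log units; beyond the scatter). Both replace a carbamoyl group with ((methoxymethyl)carbonyl)amino. Compound 4 restores a carbamoyl group, but with 2-hydroxyethyl on it rather than pyridin-2-yl or 4-methoxyphenyl, so only part of those steps is expected to reverse. The expected change is a 1.8-fold higher number from compound 3 to compound 4 (0.25 log units; within the scatter). The estimate for compound 4 is 7000 nM, within a range of 2500 nM to 20000 nM.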

Compound 4, concentration for 50% growth inhibition: 21400 nM
For compound 4 the middle estimate is 3.1-fold (0.49 log units) below the measured one, outside the stated range (above it).
By their numbers in this assay, from the lowest: compound 3; then compounds 1, 2 and 4 (each within the scatter of the next).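

In this assay, a 5.4-fold higher number from compound 3 to compound 4 (0.73 log units; beyond the scatter) shows that the carbamoyl compounds sit above compound 3 even when the aromatic group on the amide nitrogen gives way to 2-hydroxyethyl, with the heavy-atom count of the group at this position unchanged. The nitrogen substituent makes no readable difference here: a 1.4-fold higher number from compound 2 to compound 4 (0.13 log units; within the scatter) and a 1.6-fold higher number from compound 1 to compound 4 (0.19 log units; within the scatter) are both within the scatter. No measurement bears on why the two arrangements differ.

Still open, from the compounds shown here alone, is whether the lower number of compound 3 comes from the ((methoxymethyl)carbonyl)amino linkage itself or from its methoxymethyl end. An acetylamino group or a longer ether chain at this position would separate the two.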